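Notes on a methoxy-for-hydrogen step in a small series

This account rests on a few compounds, and the source may have more. Where it says the series, first, only, none or still open, it means among the compounds named here.

Measured in a functional assay on TK-10 cells (Homo sapiens) for inhibition, read by sulforhodamine B assay, with a stated time of 48 h; on this read-out higher numbers stand for weaker inhibition of growth and lower numbers for stronger inhibition of growth:

- compound 1 `COc1ccc(-c2cc(/C=C/C(=O)c3ccc(N)cc3)[nH]n2)cc1`: 13000 nM
- compound 2 `COc1ccc(-c2cc(/C=C/C(=O)c3ccc(N)cc3)[nH]n2)cc1OC`: 23000 nM
- compound 3 `COc1cc(C(=O)/C=C/c2cc(-c3cc(OC)c(OC)c(OC)c3)n[nH]2)cc(OC)c1OC`: 2800 nM

Compound 1 and compound 2 share one core; compound 3 carries a different core, and the difference between the two cores is not broken down here. Within the first pair, hydrogen in place of methoxy on an aromatic carbon produces a 1.8-fold lower number from compound 2 to compound 1 (0.25 log units; within the scatter). Compound 3 gives the lowest of the three numbers in this assay and sits beyond the scatter from both compound 1 and compound 2.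

Compound 4 `COc1ccc(-c2cc(/C=C/C(=O)c3cc(OC)c(OC)c(OC)c3)[nH]n2)cc1OC` has not yet been measured in this assay. It arises from compound 3 by hydrogen in place of methoxy on an aromatic carbon. For the measured compounds named here, this is the same kind of change as the one between compound 2 and compound 1, though not the same: the carbon on compound 3 is in addition meta to a methoxy group, which the place on compound 2 lacks. Going by the values given here, only one measured instance of this change exists here, and it lies within the scatter. The step of a 1.3-fold lower number from compound 3 to compound 4 (0.10 log units; within the scatter) is therefore expected to be small, resting on a 1.8-fold lower number from compound 2 to compound 1 (0.25 log units; within the scatter). Compound 4 is estimated at 2200 nM in this assay, with a range from 900 nM to 6000 nM.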

Compound 4, concentration for total growth inhibition: 11800 nM
Compound 4: the middle estimate sits 5.4-fold (0.73 log units) below what was measured, and the stated range ends below it.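

In this assay, hydrogen in place of methoxy on an aromatic carbon gives a 4.2-fold higher number from compound 3 to compound 4 (0.62 log units; beyond the scatter). This change therefore does not carry across the two cores as one fixed step, since its two instances differ by more than the scatter: the same change on two cores in this assay, a 1.8-fold lower number (0.25 log units; within the scatter) from compound 2 to compound 1 and a 4.2-fold higher number (0.62 log units; beyond the scatter) from compound 3 to compound 4, 7.5-fold (0.87 log units) apart, beyond the scatter of two such steps. For the compounds shown here, with only two pairs, the data do not show whether the difference follows the core as a whole or the methoxy group that is meta to the place on compound 3, and they give no rule for any further core.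

Open, as far as these compounds go, is whether a hydroxyl group, an ethoxy group or a chlorine atom at this place would give a number close to that of compound 3 or to that of compound 4, which would show whether methoxy itself is what counts here. Also open, from the compounds shown here alone, is whether a pair on the core of compound 1 with the same methoxy group meta to the place would follow the step seen on the core of compound 3.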